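Nitro in place of hydrogen on the shared core

The compounds below may be only part of what the source reports. "The series", "measured", "known", "first", "only" and "open" are said of these compounds alone.

In an ADME assay on Vero cells (Chlorocebus sabaeus) for cytotoxicity, read by MTT assay, with a stated time of 72 h (on this read-out higher numbers stand for weaker inhibition and lower numbers for stronger inhibition), compound 1 `COc1nc(C)nc(/N=C(\C)c2ccccc2)n1` stands at "not determined" (no result reported), so it offers no number to start from. Compound 2 `COc1nc(C)nc(/N=C(\C)c2cccc([N+](=O)[O-])c2)n1` gives > 50 ug/mL in this assay, which is a limit of the assay and not a number. The next structure is compound 3 `COc1nc(C)nc(/N=C(\C)c2ccc([N+](=O)[O-])cc2)n1`. The change is nitro in place of hydrogen on an aromatic carbon, para to a large group. For the measured compounds named here, no step in this assay has been measured, and none beyond the scatter is expected, an expectation resting only on the limit of compound 2 at > 50 ug/mL. In this assay the estimated value for compound 3 is 60 ug/mL, with an expected range of 25 ug/mL to 120 ug/mL.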

Compound 3, half-maximal inhibitory concentration: > 50 ug/mL
Compound 3 was reported as a limit; the forecaster's own chance of this, stated with the estimate: 75%; the middle value lies beyond the limit too.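

For the compounds shown here, no step from compound 1 to compound 3 can be read in this assay: compound 1 offers no number, and compound 3 gives > 50 ug/mL, a limit and not a number. On these data alone, whether nitro in place of hydrogen changes the read-out at all stays open.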